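Cyclopentyloxy to cyclohexyloxy on two aryl-ether cores

The source may report more compounds than this note shows. Statements on the series, on what has been measured and on what is new or still open speak of the compounds shown alone.

Two pairs of aryl ethers are compared. Compound 1 `c1cc(OC2CCCC2)ccc1NC1=NCCO1` and compound 2 `c1cc(OC2CCCCC2)ccc1NC1=NCCO1` share one core; compound 3 `O=C(CCl)NC(=O)Nc1cccc(OC2CCCC2)c1` and the unmeasured compound 4 `O=C(CCl)NC(=O)Nc1cccc(OC2CCCCC2)c1` share another. How the two cores differ is not broken down here.

In a functional assay on HT-29 cells (Homo sapiens) for inhibition, read by sulforhodamine B assay, with a stated time of 48 h (on this read-out lower numbers stand for stronger inhibition of growth and higher numbers for weaker inhibition of growth), compound 1 gives 16100 nM and compound 2 gives 12600 nM. The change between them is cyclohexyl in place of cyclopentyl on an oxygen on an aromatic ring and the step it made is a 1.3-fold lower number from compound 1 to compound 2 (0.11 log units; within the scatter). Compound 3 gives 3100 nM in this assay, the lowest of the three measured numbers, with the other two values both above it.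

The change from compound 3 to compound 4 is cyclohexyl in place of cyclopentyl on an oxygen on an aromatic ring, the same change as between compound 1 and compound 2, at a place described in the same words. It occurs twice in all among these compounds, once measured. Compound 4 is expected to sit close to compound 3, the estimated step being a 1.1-fold lower number from compound 3 to compound 4 (0.06 log units; within the scatter), because the step from compound 1 to compound 2 was a 1.3-fold lower number from compound 1 to compound 2 (0.11 log units; within the scatter). Compound 4 is therefore estimated at 2700 nM in this assay, within 1200 nM to 6000 nM.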

Compound 4, concentration for 50% growth inhibition: 3800 nM
Beside the measured number, compound 4's estimate is 1.4-fold (0.15 log units) below it; the measured number falls inside the stated range.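

In this assay, cyclohexyl in place of cyclopentyl on an oxygen on an aromatic ring gives a 1.2-fold higher number from compound 3 to compound 4 (0.09 log units; within the scatter), so this pair is not separated. On the two cores shown, the change behaves alike, with neither step resolved from the scatter: the same change on two cores in this assay, a 1.3-fold lower number (0.11 log units; within the scatter) from compound 1 to compound 2 and a 1.2-fold higher number (0.09 log units; within the scatter) from compound 3 to compound 4, 1.6-fold (0.19 log units) apart, within the scatter of two such steps. Within the data shown here, this supports carrying the change between these two cores without expecting a measurable shift in this read-out, but it rests on only two pairs and shows only that a step too small to resolve recurs, not that a larger effect would transfer from one core to the other.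

The compounds shown leave open whether any other group on the same oxygen, such as cycloheptyl, a straight butyl chain or a ring bearing an amine, would move the number beyond the scatter on either core. They also leave open whether the two cores would still respond alike to such a group.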